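The compounds below may be only part of what the source reports. "The series", "measured", "known", "first", "only" and "open" are said of these compounds alone.

Compound 1 `OCc1cn(Cc2ccccc2)c2ccccc12` gives 30 nM in a functional assay on T29Kt1 cells (Homo sapiens) for cytotoxicity, read by sulforhodamine B assay, with a stated time of 3 days (a lower number here means a stronger inhibitor, a higher number a weaker inhibitor), the lowest of the three numbers in hand. Compound 2 `OCc1cn(Cc2cccc(C(F)(F)F)c2)c2ccccc12` gives 560 nM in this assay, and compound 3 `Cc1cccc(Cn2cc(CO)c3ccccc32)c1` gives 1000 nM. Compound 4 `Cc1ccc(Cn2cc(CO)c3ccccc32)cc1` differs from compound 1 by methyl in place of hydrogen on an aromatic carbon. Among the measured compounds shown here, the steps that bear on this change are a 19-fold higher number from compound 1 to compound 2 (1.27 log units; beyond the scatter) and a 33-fold higher number from compound 1 to compound 3 (1.52 log units; beyond the scatter), each a single group placed on the same six-membered ring and each a large move to a higher number; the two substituted compounds are separated only by a 1.8-fold higher number from compound 2 to compound 3 (0.25 log units; within the scatter), which stays within the scatter. A methyl on that ring, here para to a large group, is therefore expected to give a higher number, and for compound 4 the expected step is a 20-fold higher number from compound 1 to compound 4 (1.30 log units; beyond the scatter). For compound 4 the estimate is 600 nM, with a range from 150 nM to 2500 nM.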

Compound 4, half-maximal inhibitory concentration: 150 nM
Compound 4: the middle estimate sits 4.0-fold (0.60 log units) above what was measured; measured number inside the range.
By their numbers in this assay, from the lowest: compound 1; then compound 4; then compounds 2 and 3 (each within the scatter of the next).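

Methyl para to a large group still gives a 5.0-fold higher number from compound 1 to compound 4 (0.70 log units; beyond the scatter), a modest step where the earlier ring substitutions gave large ones. Methyl elsewhere on the same ring, in compound 3, gives 1000 nM, against 150 nM for compound 4, so in this assay the outcome depends on where the methyl sits. Nothing at hand accounts for this difference.

Still open, on these data alone, is how a chlorine, a methoxy or an amine para to a large group would read. As far as these compounds go, it is also open whether any ring substituent can match compound 1, and what replacing the hydroxymethyl group would do.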